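The source may report more compounds than this note shows. Statements on the series, on what has been measured and on what is new or still open speak of the compounds shown alone.

Compound 1 `CCCN1CCN(c2ccc(S(=O)(=O)Oc3ccccc3OC)cc2)C1=O`: > 100000 nM (a limit of the assay)
Compound 2 `CCCN1CCN(c2ccc(S(=O)(=O)Oc3c(Cl)cc(Cl)cc3Cl)cc2)C1=O`: 56000 nM

Going by the values given here, in a functional assay on HT-29 cells (Homo sapiens) for antiproliferative activity, read by sulforhodamine B assay, with a stated time of 48 h (on this read-out higher numbers stand for weaker inhibition and lower numbers for stronger inhibition), compound 2 gives 56000 nM, the only true number so far. Compound 1 gives > 100000 nM, which is a limit and not a number.

Compound 3 `CCCN1CCN(c2ccc(S(=O)(=O)Oc3cccc(Cl)c3)cc2)C1=O` has not yet been measured. It differs from compound 2 by one swap: 3-chlorophenyl in place of 2,4,6-trichlorophenyl on an oxygen. This is 3-chlorophenyl in place of 2,4,6-trichlorophenyl, on the same oxygen.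

Among the compounds with values here, only one measured step concerns this group: an at least 1.7-fold lower number from compound 1 to compound 2 (0.25 log units; that floor lies within the scatter). That step is a floor and does not clear the usual scatter, so it offers no firm guide to direction. No step beyond the scatter is therefore expected in this assay, and the result may again be a limit. The estimated change is a 1.0-fold lower number from compound 2 to compound 3 (0.01 log units; within the scatter). For compound 3 the expected value is 55000 nM, with an estimated range of 20000 nM to 100000 nM.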

Compound 3, half-maximal inhibitory concentration: 13000 nM
Compound 3: middle estimate off by 4.2-fold (0.63 log units), on the high side; measured number below the stated range.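

In this assay, the group on the oxygen bound to the sulfonyl sulfur now clearly matters, with a 4.3-fold lower number from compound 2 to compound 3 (0.63 log units; beyond the scatter). Swapping 2,4,6-trichlorophenyl for 3-chlorophenyl leaves fewer chlorine atoms on the ring, so in this pair more chlorine does not mean stronger inhibition, although compound 1, with 2-methoxyphenyl and no chlorine, goes against any simple rule that less chlorine is better. The comparison with 2-methoxyphenyl gives an at least 7.6-fold lower number from compound 1 to compound 3 (0.88 log units; beyond the scatter), and this size is only a floor, as compound 1 gives a limit and not a number: the limit of > 100000 nM in this assay, at which 1 of the 3 values shown sits.

From the compounds shown here alone, whether the lower number follows the count of chlorine atoms or where they sit on the ring stays open. The compounds shown also do not tell how a plain phenyl or a 3-bromophenyl group on this oxygen would compare.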